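The source may hold more compounds than are shown below. What is called first, only, known or untested is meant among the compounds shown, and "the series" means these compounds.

Measured so far in an assay on COS-7 cells for inhibition of patatin-like phospholipase domain-containing protein 2 (Mus musculus); on this read-out higher numbers stand for weaker inhibition and lower numbers for stronger inhibition:

compound 1 `CCOC(=O)c1ccnc(-c2ccc(OCC)cc2)c1` gives 80000 nM
compound 2 `CCOC(=O)c1cccc(-c2ccc(CN3CCN(S(C)(=O)=O)CC3)o2)c1` gives 100000 nM
compound 3 `CCOc1ccc(-c2cccc(S(=O)(=O)N(C)C)c2)cc1` gives 110000 nM

The three numbers lie close together; the gaps from compound 3 to compound 2 and to compound 1 both sit within the usual scatter, so nothing separates compound 3 from the other two on this read-out. No pair of these compounds differs in only one place, so no single step between measured compounds can be drawn on.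

Compound 4 `CCOc1ccc(-c2cccc(C(=O)NC)c2)cc1` has not yet been measured. It is compound 3 with methylcarbamoyl in place of dimethylsulfamoyl on an aromatic carbon. Among the compounds with values here, nothing among the measured compounds shows what such a change does here, and all three numbers are weak and alike. On that ground the step from compound 3 to compound 4 is expected to stay within the scatter, with no direction favoured, and the estimate is a 1.1-fold lower number from compound 3 to compound 4 (0.04 log units; within the scatter). Compound 4 is accordingly expected to give about 100000 nM in this assay, somewhere between 40000 nM and 250000 nM.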

Compound 4, half-maximal inhibitory concentration: > 200000 nM
Compound 4 was reported as a limit; the forecaster's own chance of this, stated with the estimate: 30%; middle value at least 2.0-fold (0.30 log units) from the limit.
By their numbers in this assay, from the lowest: compounds 1, 2 and 3 (each within the scatter of the next). At a limit, above all of these: compound 4.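

Within the data shown here, putting methylcarbamoyl in place of dimethylsulfamoyl on this aromatic carbon gives the first step in one place that can be read in this assay (an at least 1.8-fold higher number from compound 3 to compound 4 (0.25 log units; that floor lies within the scatter)), and it brings no gain in inhibition. Compound 4 is reported only as a limit (> 200000 nM). How far the step reaches past its floor therefore cannot be read, so the data do not show whether this change matters much or little: (the limit of > 200000 nM in this assay, at which 1 of the 4 values shown sits).

On these data alone, what a carboxylic acid, an amine or a longer sulfonyl chain would do on this same aromatic carbon stays open. Among these compounds, also open is whether changing the ethoxy group while keeping dimethylsulfamoyl would move the number in either direction, and with only one step at this position, no trend can be drawn for it.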